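The compounds below may be only part of what the source reports. "The series", "measured", "known", "first", "only" and "open" are said of these compounds alone.

Working notes on the series.

The series is read in a functional assay on MGC-803 cells (Homo sapiens) for inhibition, read by MTT assay, with a stated time of 72 h; a lower number here means a stronger inhibitor, a higher number a weaker inhibitor. Among the compounds with values here, compound 1, `CC(C)(C)OC(=O)N1CCN(C(=S)SCc2cn(Cc3ccc(Cl)cc3)nn2)CC1`, is the only member with a number: in this assay compound 1 gives 9790 nM. Compound 2, `COc1cc(Cn2cc(CSC(=S)N3CCNCC3)nn2)cc(OC)c1OC`, carries a free ring nitrogen on the shared core; in this assay compound 2 gives "not determined" (no result reported), so no number stands for it. Compound 3, `S=C(SCc1cn(Cc2ccc(Cl)cc2)nn1)N1CCNCC1`, is in the same position: in this assay compound 3 gives "not determined" (no result reported). Compound 2 therefore stands nowhere on the numbers shown; it can be ranked against neither compound 1 nor compound 3.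

Compound 4, `COc1cc(Cn2cc(CSC(=S)N3CCN(C(=O)OCc4ccccc4)CC3)nn2)cc(OC)c1OC`, is the next member to go into this assay. It differs from compound 2 by a single change: benzyloxycarbonyl in place of hydrogen on an amine nitrogen in a ring. Within the data shown here, no step between two measured compounds is known for this change, and compound 2 itself has no number, so the size of the step cannot be set against a measured pair. Among the measured compounds shown here, the only anchor is compound 1, whose ring nitrogen also bears a carbamate group and which gives 9790 nM in this assay.

On that anchor alone, compound 4 is expected to land near the same region of this assay, estimated at 8000 nM with a range from 2500 nM to 25000 nM.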

Compound 4, half-maximal inhibitory concentration: 10900 nM
Estimate against measurement, compound 4: 1.4-fold (0.13 log units) below; the measured number falls inside the stated range.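

No new step can be read from compound 4: compound 2, its one-change partner, has no number in this assay, and compound 1 differs from it in more than one place. No measurement shown here bears on the result. The compounds shown leave open how hydrogen and benzyloxycarbonyl on that ring nitrogen compare in this assay.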